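A Carboxy-Methylphenyl Sulfonamide Against Carboxylesterase Inhibition

This account rests on a few compounds, and the source may have more. Where it says the series, first, only, none or still open, it means among the compounds named here.

Three bis-sulfonamides have been measured in an assay for inhibition of liver carboxylesterase 1 (Homo sapiens), read by spectrophotometry; on this read-out higher numbers stand for weaker inhibition and lower numbers for stronger inhibition. Compound 1 `O=C(O)c1ccc(S(=O)(=O)Nc2ccc(NS(=O)(=O)c3ccc(F)cc3)cc2)cc1` carries a carboxy group on an aromatic carbon, and in this assay compound 1 returns only a limit, > 100000 nM. Compound 2 `O=S(=O)(Nc1ccc(NS(=O)(=O)c2ccc(F)cc2)cc1)c1ccc(F)cc1` has fluoro in place of that carboxy group, and in this assay compound 2 likewise returns only a limit, > 100000 nM. Compound 3 `O=S(=O)(Nc1ccc(NS(=O)(=O)c2ccc(Cl)cc2)cc1)c1ccc(F)cc1` has chloro on that aromatic carbon, and in this assay compound 3 again stands at a limit, > 100000 nM. The steps a step that the two limits leave unreadable from compound 1 to compound 2, a step that the two limits leave unreadable from compound 1 to compound 3 and a step that the two limits leave unreadable from compound 2 to compound 3 cannot be read, since all three values sit at the limit of > 100000 nM in this assay, at which 3 of the 3 values shown sit.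

Compound 4 `Cc1ccc(C(=O)O)cc1S(=O)(=O)Nc1ccc(NS(=O)(=O)c2ccc(F)cc2)cc1` differs from compound 3 by 5-carboxy-2-methylphenyl in place of 4-chlorophenyl on a sulfonyl sulfur. Among the measured compounds shown here, no measured step bears on this change in a readable way. For the measured compounds named here, the only guide is compound 1, which also carries a carboxy group and stays at a limit. Compound 4 is therefore expected to show no readable step, the estimated step that the limit leaves unreadable from compound 3 to compound 4 being uncertain in size. Compound 4 is estimated at 150000 nM in this assay, with a range from 30000 nM to 1000000 nM, most likely reported only as a limit.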

Compound 4, inhibition constant: > 100000 nM
Compound 4 ended at the assay's limit; the forecaster's own chance of this, stated with the estimate: 80%; the middle value is on the limit's open side.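

Among the compounds shown here, compound 4 also returns only a limit in this assay, so no step from compound 1, compound 2 or compound 3 to compound 4 can be read: the limit of > 100000 nM in this assay, at which 4 of the 4 values shown sit. The compounds shown leave open how strongly any of them inhibits in this assay and whether any group on the sulfonyl sulfur changes that inhibition.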